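Cyanomethyl in place of 2-chlorobenzyl on two cores

This account rests on a few compounds, and the source may have more. Where it says the series, first, only, none or still open, it means among the compounds named here.

Measured so far in an ADME assay on MT4 cells (Homo sapiens) for cytotoxicity, read by MTT assay, with a stated time of 5 days; a lower number here means that less compound is tolerated, a higher number that more compound is tolerated:
compound 1 `N#CCN1C(=O)N(Cc2cccc(F)c2)S(=O)(=O)n2cccc21`: 172000 nM
compound 2 `O=C1N(Cc2ccccc2Cl)c2cccn2S(=O)(=O)N1Cc1cccc(F)c1`: 231000 nM
compound 3 `O=C1N(Cc2ccccc2Cl)c2cscc2S(=O)(=O)N1Cc1ccccc1`: > 119000 nM, which is a limit of the assay and not a number

Within the pair sharing the core of compound 2, the change cyano in place of 2-chlorophenyl on a saturated chain carbon bound to an amide-type nitrogen in a ring gave a 1.3-fold lower number from compound 2 to compound 1 (0.13 log units; within the scatter), so both values sit together without any order between them. For compound 3 the result stands only as a limit, (the limit of > 119000 nM in this assay, at which 1 of the 3 values shown sits). How the core of compound 3 differs from the core of compound 2 is not broken down here.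

Compound 4 `N#CCN1C(=O)N(Cc2ccccc2)S(=O)(=O)c2cscc21` has not yet been measured in this assay. It stands to compound 3 as compound 1 stands to compound 2: the same change, (cyano in place of 2-chlorophenyl on a saturated chain carbon bound to an amide-type nitrogen in a ring), at the same place. Because a 1.3-fold lower number from compound 2 to compound 1 (0.13 log units; within the scatter) lay within the scatter, the step from compound 3 to compound 4 is expected to be of like size, a step that the limit leaves unreadable from compound 3 to compound 4, and the limit of compound 3, (the limit of > 119000 nM in this assay, at which 1 of the 3 values shown sits), makes a further limit a real possibility. Compound 4 is therefore expected to give about 150000 nM, estimated between 70000 nM and 320000 nM.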

Compound 4, half-maximal cytotoxic concentration: 503000 nM
The estimate for compound 4 lay 3.4-fold (0.53 log units) below the measured number; the measured number lies above the stated range.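

No step can be read from compound 3 to compound 4 because the result for compound 3 is a limit and not a number: the limit of > 119000 nM in this assay, at which 1 of the 4 values shown sits.

The compounds shown leave open how 2-chlorobenzyl to cyanomethyl shifts the number on the core of compound 3, and whether that shift matches the one on the core of compound 2.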